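The source may hold more compounds than are shown below. What is called first, only, known or untested is meant among the compounds shown, and "the series" means these compounds.

This study follows a small set of compounds built on one shared core, each carrying a different group on an aromatic carbon. In a physicochemical assay for lipophilicity, measured as octanol-water partition, at pH 7.4 (a higher number here means a more lipophilic compound, a lower number a more polar compound), compound 1 `Cn1cc(-c2ccc(N(C(=O)NCc3ccccc3)[C@H]3CC[C@H](Nc4ccc(C#N)cn4)CC3)cc2)ccc1=O` gives 2.4. Compound 2 `Cn1cc(-c2ccc(N(C(=O)NCc3ccccc3)[C@H]3CC[C@H](Nc4ccc(C#N)cn4)CC3)cc2)cn1` gives 2.8 in this assay, and compound 3 `N#Cc1ccc(N[C@H]2CC[C@H](N(C(=O)NCc3ccccc3)c3ccc(-c4cccnc4)cc3)CC2)nc1` gives 3. Among the three measured numbers compound 3 stands highest: the step of a number 0.20 log units higher from compound 2 to compound 3 (within the scatter) is within the scatter, while the step of a number 0.60 log units higher from compound 1 to compound 3 (beyond the scatter) is beyond it.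

Compound 4 `Cn1c(-c2ccc(N(C(=O)NCc3ccccc3)[C@H]3CC[C@H](Nc4ccc(C#N)cn4)CC3)cc2)cccc1=O` has not yet been measured in this assay. The change from compound 3 is a group of 8 heavy atoms (6 carbon, 1 nitrogen, 1 oxygen; one six-membered aromatic ring with 1 hetero atom) in place of a group of 6 heavy atoms (5 carbon, 1 nitrogen; one six-membered aromatic ring with 1 hetero atom), on an aromatic carbon. The pyridin-3-yl, with 5 carbon and 1 nitrogen, leaves, and a group of 8 heavy atoms with 1 oxygen and 1 double bond outside aromatic rings enters, on an aromatic carbon para to a large group.

The measured step that bears most directly on this is a number 0.60 log units higher from compound 1 to compound 3 (beyond the scatter), where a group of the same size and make-up as the one now entering was replaced by pyridin-3-yl. The present change runs in the opposite direction, so a modest step downward, beyond the scatter, is expected. The step of a number 0.40 log units higher from compound 1 to compound 2 (beyond the scatter) points the same way, since compound 1, carrying the oxygen-bearing group, gives the lowest number measured.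

Compound 4 is therefore expected to give 2.4, within a range of 2 to 2.9. This estimate means an expected step of a number 0.60 log units lower from compound 3 to compound 4 (beyond the scatter).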

Compound 4, distribution coefficient: 2.6
Compound 4: middle estimate off by 0.20 log units, on the low side; low and high end bracket the measured number.
By their numbers in this assay, from the lowest: compounds 1, 4, 2 and 3 (each within the scatter of the next, the first and the last beyond it).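

Among the compounds shown here, compound 4 carries a group of the same size and make-up as the one in compound 1, with the atoms arranged differently, and in this assay that rearrangement on an aromatic carbon para to a large group gives a step that cannot be told from noise (a number 0.20 log units higher from compound 1 to compound 4 (within the scatter)). Against pyridin-3-yl the new group still gives a step beyond the scatter (a number 0.40 log units lower from compound 3 to compound 4 (beyond the scatter)), so the gap first seen between compound 1 and compound 3 now appears with a second arrangement of this group, which makes it less likely to depend on one particular arrangement. Against 1-methyl-1H-pyrazol-4-yl the step stays within the scatter (a number 0.20 log units lower from compound 2 to compound 4 (within the scatter)), so compound 4 cannot be separated from compound 2 or from compound 1, even though those two are separated from each other (a number 0.40 log units higher from compound 1 to compound 2 (beyond the scatter)).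

Nothing in the data explains why these groups give the numbers they do. All four groups shown are aromatic rings, so it remains open where a non-aromatic group at this place, such as a morpholine ring or a carboxylic acid, would fall relative to them.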